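Swapping the Aryl Group on a Ring Nitrogen

The compounds below may be only part of what the source reports. "The series", "measured", "known", "first", "only" and "open" are said of these compounds alone.

Compound 2 `Nc1scc(CN2CCN(c3cccc(Cl)c3Cl)CC2)c1C(=O)c1ccc(Cl)cc1` is one of three close relatives measured in a functional assay on CHO cells with adenosine receptor A1 (Homo sapiens) as the target, read by cAMP accumulation and immunoassay, with a stated time of 6 min, tested at 0.01 uM; on this read-out lower numbers stand for a stronger effect and higher numbers for a weaker effect at the one concentration tested. In this assay compound 2 gives 1%, the middle of the three numbers, all of which lie within the scatter of one another. Compound 1 `Nc1scc(CN2CCN(c3ccc(Cl)cc3Cl)CC2)c1C(=O)c1ccc(Cl)cc1` gives 2%, and compound 3 `COc1ccc(N2CCN(Cc3csc(N)c3C(=O)c3ccc(Cl)cc3)CC2)cc1` gives -1.2%. The three differ only in the group on an amine nitrogen in a ring, and every step between them stayed within the scatter: a number 1 percentage points lower from compound 1 to compound 2 (within the scatter), a number 3.2 percentage points lower from compound 1 to compound 3 (within the scatter) and a number 2.2 percentage points lower from compound 2 to compound 3 (within the scatter). Compound 4 `Nc1scc(CN2CCN(c3ccc([N+](=O)[O-])cc3)CC2)c1C(=O)c1ccc(Cl)cc1` changes the same place: 4-nitrophenyl in place of 2,3-dichlorophenyl on an amine nitrogen in a ring. Because a number 2.2 percentage points lower from compound 2 to compound 3 (within the scatter) and the other two steps at this spot stayed within the scatter, no step beyond the scatter is expected here either. The expected step is no change at the digits printed from compound 2 to compound 4 (within the scatter). Compound 4 is therefore estimated at 1%, between -9% and 11%.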

Compound 4, a percentage reported as activity, at one concentration (the size of the read-out at that concentration, not a potency): -12%
The estimate for compound 4 lay 13 percentage points above the measured number; measured number outside the range, below it.
By their numbers in this assay, from the lowest: compound 4; then compounds 3, 2 and 1 (each within the scatter of the next).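

The aryl group on this ring nitrogen can matter in this assay: there is a number 13 percentage points lower from compound 2 to compound 4 (beyond the scatter), a number 14 percentage points lower from compound 1 to compound 4 (beyond the scatter) and a number 10.8 percentage points lower from compound 3 to compound 4 (beyond the scatter). Each step points toward a stronger effect, so 4-nitrophenyl stands apart from the other three aryl groups, which remain within the scatter of one another. No measurement shown here accounts for this difference.

Only one nitro compound is shown, so it remains open whether the shift is specific to nitro. A nitrile or a carboxylic acid in its place could help answer that.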